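Taking the Chloro Off Compound 1

The source may report more compounds than this note shows. Statements on the series, on what has been measured and on what is new or still open speak of the compounds shown alone.

In a functional assay on A549 cells (Homo sapiens) for cytotoxicity, read by MTT assay, with a stated time of 72 h (a lower number here means a stronger inhibitor, a higher number a weaker inhibitor), compound 1 `CN(C)Cc1ccc2nc(NC(=O)N/N=C/c3cn(Cc4ccccc4Cl)c4ccccc34)sc2c1` gives 1080 nM. Among the measured compounds shown here, that is the lower of the two numbers measured so far, which makes it the stronger inhibitor of the pair. The other measured compound, compound 2 `CCN(CC)Cc1ccc2nc(NC(=O)N/N=C/c3cn(Cc4cccc(Cl)c4)c4ccccc34)sc2c1`, gives 2410 nM, and this gap lies beyond the usual scatter of repeated measurements. Compound 2 differs from compound 1 in more than one place, so the pair cannot show what the chloro alone contributes.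

The next compound makes a single change. Compound 3 `CN(C)Cc1ccc2nc(NC(=O)N/N=C/c3cn(Cc4ccccc4)c4ccccc34)sc2c1` has hydrogen in place of chloro on an aromatic carbon, ortho to a large group, turning the 2-chlorobenzyl of compound 1 into a plain benzyl: hydrogen in place of chloro on an aromatic carbon. For the measured compounds named here, no measured pair shows this exchange, so the forecast is cautious and its range is wide. In this assay the expected change is small and towards a higher number, a slightly weaker inhibitor, and the estimated step is a 1.6-fold higher number from compound 1 to compound 3 (0.20 log units; within the scatter). For compound 3 the estimated value is 1700 nM, with an expected range from 600 nM to 4500 nM.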

Compound 3, half-maximal inhibitory concentration: 2900 nM
Compound 3: the middle estimate sits 1.7-fold (0.23 log units) below what was measured, and the stated range covers the measured number.
By their numbers in this assay, from the lowest: compound 1; then compounds 2 and 3 (each within the scatter of the next).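

In this assay, taking the chloro off the 2-chlorobenzyl group gives a 2.7-fold higher number from compound 1 to compound 3 (0.43 log units; beyond the scatter), a modest step but one beyond the usual scatter, so a chloro at this place, ortho to a large group, goes with the stronger inhibitor of this pair. The earlier comparison could not show this, as compound 2 differs from compound 1 in more than one place, whereas here a single atom is exchanged and everything else in the molecule stays the same. No measurement at hand says what lies behind this step.

This single pair cannot say whether the effect is particular to chlorine, or whether another group at the same place, such as fluoro, bromo or methoxy, would give a similar number, a lower one or a higher one. It also leaves open what a chloro elsewhere on the benzyl would do with the rest of compound 1 unchanged, since compound 2 carries its chloro at a different place but also differs from compound 1 in another part of the molecule.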